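Methyl in Place of Methoxy: What to Expect for Compound 4

The source may hold more compounds than are shown below. What is called first, only, known or untested is meant among the compounds shown, and "the series" means these compounds.

Of the compounds shown here, three sharing one core have been tested in a functional assay on B16-F10 cells (Mus musculus) for antiproliferative activity, read by MTT assay, with a stated time of 48 h; a higher number here means a weaker inhibitor, a lower number a stronger inhibitor. Compound 1 `COc1ccc(-c2nn(-c3ccccc3)cc2CNc2ccc(F)cc2)cc1` gives 6580 nM, compound 2 `COc1ccc(-c2nn(-c3ccccc3)cc2CNc2ccc(C)cc2)cc1` gives 8380 nM, and compound 3 `Clc1ccc(NCc2cn(-c3ccccc3)nc2-c2ccc(Br)cc2)cc1` gives 4290 nM. Compound 2 shows the highest of the three numbers, yet the single-point step that leads up to it (a 1.3-fold higher number from compound 1 to compound 2 (0.11 log units; within the scatter)) lies within the scatter, and its gap to compound 3 is likewise within the scatter, so none of the three can be set apart from the others.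

Compound 4 `Cc1ccc(NCc2cn(-c3ccccc3)nc2-c2ccc(C)cc2)cc1` differs from compound 2 in one place: methyl in place of methoxy on an aromatic carbon. Among the compounds with values here, no measured step exchanges a methoxy for a methyl. Within the data shown here, the only single-point step, the exchange of fluoro for methyl seen between compound 1 and compound 2, stays within the scatter, and compound 3 differs from compound 2 in two places, so it gives no step to read. With nothing bearing directly on this change, the number for compound 4 is expected to stay close to that of compound 2, with a shift of a 1.0-fold lower number from compound 2 to compound 4 (0.02 log units; within the scatter) expected. Compound 4 is therefore estimated at 8000 nM, between 3500 nM and 18000 nM.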

Compound 4, half-maximal inhibitory concentration: 7380 nM
Compound 4: middle estimate off by 1.1-fold (0.04 log units), on the high side; the range from low to high includes it.
By their numbers in this assay, from the lowest: compounds 3, 1, 4 and 2 (each within the scatter of the next).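

Within the data shown here, exchanging 4-methoxyphenyl for 4-methylphenyl is the first single change at this position that can be read directly, and in this assay it gives a 1.1-fold lower number from compound 2 to compound 4 (0.06 log units; within the scatter). The exchange takes away one heavy atom and the one hydrogen-bond acceptor of the methoxy group, yet compound 2 and compound 4 cannot be told apart in this measurement, so at this position that difference leaves no readable mark. No measurement shown here offers an explanation for this result.

Methoxy and methyl both carry no net charge, so it remains open whether a group of another kind here, such as an amine, a carboxylic acid or a longer chain, would set a compound apart from compound 2. On these data alone, this is also a single pair, so it remains open whether the same exchange would read alike on the background of compound 1, which has fluoro in place of the other methyl.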